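From 3-phenylpropyl to phenyl on a saturated chain

The source may report more compounds than this note shows. Statements on the series, on what has been measured and on what is new or still open speak of the compounds shown alone.

Measured so far in a functional assay on NCI-H630 cells (Homo sapiens) for cytotoxicity, read by sulforhodamine B assay, with a stated time of 5 days; on this read-out higher numbers stand for weaker inhibition and lower numbers for stronger inhibition:
- compound 1 `O=C(CCCCCCc1ccccc1)CC(=O)N[C@H]1CCOC1=O` gives 27000 nM
- compound 2 `O=C(CCCCCCCCCCc1ccccc1)CC(=O)N[C@H]1CCOC1=O` gives 14000 nM

These two values lie within the scatter of each other, so compound 2 does not stand apart from compound 1 on these numbers. Compound 3 `O=C(CCCCCCCc1ccccc1)CC(=O)N[C@H]1CCOC1=O` has not yet been measured. It differs from compound 2 by one change (phenyl in place of 3-phenylpropyl on a saturated chain carbon, seven bonds along the chain from a carbonyl carbon), with phenyl in place of 3-phenylpropyl on a saturated chain carbon, seven bonds along the chain from a carbonyl carbon. Going by the values given here, no step between measured compounds is available as a guide. Compound 1 at 27000 nM and compound 2 at 14000 nM offer no clear trend, so no step beyond the scatter is expected in this assay. The expected change is a 1.5-fold higher number from compound 2 to compound 3 (0.18 log units; within the scatter), and no firm direction is implied. For compound 3 the estimate is 21000 nM, with an expected range from 10000 nM to 45000 nM.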

Compound 3, half-maximal inhibitory concentration: 10000 nM
Estimate against measurement, compound 3: 2.1-fold (0.32 log units) above, and the stated range covers the measured number.
By their numbers in this assay, from the lowest: compounds 3, 2 and 1 (each within the scatter of the next, the first and the last beyond it).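

In this assay, phenyl in place of 3-phenylpropyl on a saturated chain carbon, seven bonds along the chain from a carbonyl carbon, gives a 1.4-fold lower number from compound 2 to compound 3 (0.15 log units; within the scatter), so this exchange does not separate the two compounds. Benzyl in place of phenyl on a saturated chain carbon, six bonds along the chain from a carbonyl carbon, gives a 2.7-fold lower number from compound 1 to compound 3 (0.43 log units; beyond the scatter), the only step here that clears the scatter, and it is a modest one. Nothing measured here explains the size of either step.

On these data alone, compound 2 lies within the scatter of both compound 1 and compound 3, so whether the number follows chain length stays open. The compounds shown also leave open how the number would respond to an amine or a carboxylic acid in place of the phenyl.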